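This account rests on a few compounds, and the source may have more. Where it says the series, first, only, none or still open, it means among the compounds named here.

Values in an ADME assay on microsomes from liver (Homo sapiens) for metabolic stability (a lower number here means that the compound disappears faster, a higher number that the compound lasts longer), for the measured members of the series:

compound 1, `CC(C)C(c1ncc[nH]1)c1ccc(-c2ccc3cccc(F)c3c2)[nH]c1=O`: < 0.0667 h
compound 2, `CC(C)NC(=O)CC(c1ccc(-c2ccc3cccc(F)c3c2)[nH]c1=O)C(C)C`: 0.32 h
compound 3, `CC(C)C(Nc1nccs1)c1ccc(-c2ccc3cccc(F)c3c2)[nH]c1=O`: 0.17 h

The value of compound 1 is a limit of the assay and not a number. For the measured compounds named here, compound 3 sits within the scatter of compound 2, as the step of a 1.9-fold lower number from compound 2 to compound 3 (0.27 log units; within the scatter) shows, and the only other value is the limit of compound 1, so compound 3 cannot be placed above or below compound 2 on these numbers.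

Compound 4, `CC(C)C(c1ccc(-c2ccc3cccc(F)c3c2)[nH]c1=O)N1CCN/C1=N\C#N`, differs from compound 3 at the substituent on the saturated chain carbon bound to an aromatic carbon and a saturated chain carbon: a group of 8 heavy atoms (4 carbon, 4 nitrogen; one five-membered non-aromatic ring with 2 hetero atoms) in place of a group of 6 heavy atoms (3 carbon, 2 nitrogen, 1 sulfur; one five-membered aromatic ring with 2 hetero atoms), on a saturated chain carbon bound to an aromatic carbon and a saturated chain carbon.

Two measured steps change this same position. From the imidazolyl of compound 1 the step of an at least 2.5-fold higher number from compound 1 to compound 3 (0.40 log units; beyond the scatter) was at least modest, and an at least 4.7-fold higher number from compound 1 to compound 2 (0.68 log units; beyond the scatter) likewise; between the two groups that give numbers, a 1.9-fold lower number from compound 2 to compound 3 (0.27 log units; within the scatter) stays within the scatter. Going by the values given here, no measured step involves a non-aromatic ring or a nitrile at this position, so the direction for compound 4 rests on the spread between compound 2 and compound 3 alone. For compound 4 a step of a 1.3-fold higher number from compound 3 to compound 4 (0.11 log units; within the scatter) is expected, that is, no change beyond the scatter. The estimate for compound 4 in this assay is 0.22 h, with a range from 0.08 h to 0.55 h.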

Compound 4, half-life: 0.632 h
Compound 4: middle estimate off by 2.9-fold (0.46 log units), on the low side; the whole stated range lies below it.
By their numbers in this assay, from the lowest: compounds 3, 2 and 4 (each within the scatter of the next, the first and the last beyond it). At a limit, below all of these: compound 1.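

In this assay, for the compounds shown here, the replacement of (1,3-thiazol-2-yl)amino by the five-membered non-aromatic ring carrying a nitrile gives a 3.7-fold higher number from compound 3 to compound 4 (0.57 log units; beyond the scatter), the first step beyond the scatter at this position in which both ends are numbers, since the earlier pair of numbers stayed within it. Against the open-chain (isopropylcarbamoyl)methyl group the same ring gives a 2.0-fold higher number from compound 2 to compound 4 (0.30 log units; within the scatter), so compound 2 cannot be separated from either compound 3 or compound 4, even though those two differ from each other beyond the scatter. Compound 1 gives a limit of the assay and not a number, and its step to the new ring reads an at least 9.4-fold higher number from compound 1 to compound 4 (0.97 log units; beyond the scatter), which fixes only a minimum size: the limit of < 0.0667 h in this assay, at which 1 of the 4 values shown sits.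

The compounds shown do not tell whether the step from compound 3 to compound 4 belongs to the non-aromatic ring, to the nitrile or to the two together, and the same ring with a carbonyl in place of the nitrile-bearing nitrogen would separate these. From the compounds shown here alone, how a plain amine or a carboxylic acid on this saturated chain carbon would read in this assay also remains open.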